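The source may report more compounds than this note shows. Statements on the series, on what has been measured and on what is new or still open speak of the compounds shown alone.

In a physicochemical assay for acid dissociation, compound 3 `CC(=O)OCCCCc1ccc(S(N)(=O)=O)cc1` gives 10.5. Compound 2 `CC(=O)OCCCc1ccc(S(N)(=O)=O)cc1` gives 10.2, which lies within the scatter of that number. Compound 1 `CC(C)CNCCCS(=O)(=O)c1ccc(S(N)(=O)=O)s1`, built on a different core, gives 9.3, and its gap to compound 3 lies beyond the scatter.

The next molecule is compound 4 `NS(=O)(=O)c1ccc(CCCCCO)cc1`, and the change from compound 3 is hydroxymethyl in place of acetoxy on a saturated chain carbon, four bonds along the chain from an aromatic carbon. In words, hydroxymethyl takes the place of acetoxy on a saturated chain carbon, four bonds along the chain from an aromatic carbon. The ester at the end of the chain is therefore gone, and the chain ends in an alcohol.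

Among the measured compounds shown here, no measured pair shows this exact swap, so the evidence is indirect. The nearest guide is a number 0.30 log units higher from compound 2 to compound 3 (within the scatter), where acetoxymethyl replaces acetoxy on a saturated chain carbon. That change further out on the chain left the number within the scatter, and compound 1 differs too widely from compound 3 to isolate any single change.

On that thin basis, the expected result is a number 0.20 log units lower from compound 3 to compound 4 (within the scatter), which would be no real shift beyond the scatter. The estimated value for compound 4 is 10.3, with an expected range of 9.9 to 10.7.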

Compound 4, acid dissociation constant: 10.3
Beside the measured number, compound 4's estimate shows no gap at the digits printed; low and high end bracket the measured number.
By their numbers in this assay, from the lowest: compound 1; then compounds 2, 4 and 3 (each within the scatter of the next).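

In this assay the earlier pair only changed the length of a chain ending in an ester, whereas this result changes the chain end itself: with hydroxymethyl in place of acetoxy on a saturated chain carbon, four bonds along the chain from an aromatic carbon, there is a number 0.20 log units lower from compound 3 to compound 4 (within the scatter) on the shared core. A second comparison gives a number 0.10 log units higher from compound 2 to compound 4 (within the scatter) when 2-hydroxyethyl takes the place of acetoxy on a saturated chain carbon, three bonds along the chain from an aromatic carbon, so neither route to the alcohol moves the read-out beyond the scatter. Nothing available here gives a reason for this result.

These three compounds on the shared core cover only an alcohol and two esters, so a chain ending in a carboxylic acid or a primary amine remains an open case. As far as these compounds go, it is also open whether a longer chain ending in the same alcohol would stay within the scatter of compound 4 or move clearly away from it.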